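The compounds below may be only part of what the source reports. "The series", "measured", "known", "first", "only" and "open" are said of these compounds alone.

Measured compounds:
Compound 1 `CC(=O)OC[C@H]1O[C@H](OC[C@@H](Cn2cc(CN(c3nc(-c4ccc(Cl)cc4)no3)C3CCCCC3)nn2)OC(C)=O)C=C[C@@H]1OC(C)=O` gives 35.5 ug/mL.
Compound 2 `CC(=O)OC[C@H]1O[C@H](OC[C@@H](Cn2cc(CN(c3nc(-c4ccccc4)no3)C3CCCCC3)nn2)OC(C)=O)C=C[C@@H]1OC(C)=O` gives 28.6 ug/mL.
Compound 3 `CC(=O)OC[C@H]1O[C@H](OC[C@@H](Cn2cc(CN(c3nc(-c4ccc(Br)cc4)no3)C3CCCCC3)nn2)OC(C)=O)C=C[C@@H]1OC(C)=O` gives 39.1 ug/mL.

All three were tested in an ADME assay on RAW264.7 cells (Mus musculus) for cytotoxicity, read by MTT assay, with a stated time of 48 h; on this read-out lower numbers stand for higher toxicity in this test and higher numbers for lower toxicity in this test. Compound 3 has the highest of the three numbers, but its neighbours sit close: a 1.1-fold higher number from compound 1 to compound 3 (0.04 log units; within the scatter) and a 1.4-fold higher number from compound 2 to compound 3 (0.14 log units; within the scatter), so the three values cannot be told apart on this read-out.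

Compound 4 `CC(=O)OC[C@H]1O[C@H](OC[C@@H](Cn2cc(CN(c3nc(-c4cccc([N+](=O)[O-])c4)no3)C3CCCCC3)nn2)OC(C)=O)C=C[C@@H]1OC(C)=O` is the next compound to be measured in this assay. Its change from compound 3 is 3-nitrophenyl in place of 4-bromophenyl on an aromatic carbon.

Among the compounds with values here, three measured steps touch the same aromatic carbon: a 1.2-fold lower number from compound 1 to compound 2 (0.09 log units; within the scatter), a 1.1-fold higher number from compound 1 to compound 3 (0.04 log units; within the scatter) and a 1.4-fold higher number from compound 2 to compound 3 (0.14 log units; within the scatter). Each swapped chloro, bromo or hydrogen on that ring, and none moved the number beyond the scatter. Within the data shown here, no measured compound carries a nitro group, and no measured step covers the 3-nitrophenyl group, so the data give no direct guide to it; the prior steps only suggest that changing this group has so far left the number roughly where it was.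

Compound 4 is therefore expected to give about 34 ug/mL, with a range from 17 ug/mL to 68 ug/mL. This estimate means an expected step of a 1.2-fold lower number from compound 3 to compound 4 (0.06 log units; within the scatter), which is expected to stay within the scatter.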

Compound 4, half-maximal cytotoxic concentration: 100 ug/mL
The estimate for compound 4 lay 2.9-fold (0.47 log units) below the measured number; the measured number lies above the stated range.
By their numbers in this assay, from the lowest: compounds 2, 1 and 3 (each within the scatter of the next); then compound 4.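

In this assay, within the data shown here, hydrogen, chloro and bromo on the phenyl ring left the number within the scatter, and the 3-nitrophenyl group is the first change here to go beyond it (a 2.6-fold higher number from compound 3 to compound 4 (0.41 log units; beyond the scatter)) and (a 2.8-fold higher number from compound 1 to compound 4 (0.45 log units; beyond the scatter)). Among these compounds, the clearest comparison starts from the unsubstituted phenyl ring of compound 2, where the only change is the added nitro group (a 3.5-fold higher number from compound 2 to compound 4 (0.54 log units; beyond the scatter)), and it shows that this position can respond, in the direction of lower toxicity in this test. Nothing available here explains the shift.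

Compounds 1 and 3 carry their halogen at a different ring place from the nitro group of compound 4, so these compounds cannot separate the effect of the nitro group itself from the effect of where it sits on the ring. Going by these compounds, whether another group at this place, such as an amine, a carboxylic acid or a nitrile, would also raise the number remains open, as does whether the rise is particular to nitro.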